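The compounds below may be only part of what the source reports. "The series", "measured", "known", "first", "only" and "open" are said of these compounds alone.

In a functional assay on HeLa cells (Homo sapiens) for inhibition, read by MTT assay, with a stated time of 72 h (a higher number here means a weaker inhibitor, a lower number a stronger inhibitor), compound 1 (`COc1cc(NC(=O)/C=C/c2cccc(OCc3ccccc3)c2)cc(OC)c1OC`) gives 2200 nM. In the same read-out, compound 3 (`C=C(Br)C(=O)Nc1cccc(/C=C/C(=O)Nc2cccc(F)c2)c1`) gives 1200 nM, which lies within the scatter of the compound 1 value, so these two cannot be ranked. Compound 2 (`C=C(Br)C(=O)Nc1cccc(/C=C/C(=O)Nc2ccc(F)cc2)c1`) stands well apart at 16800 nM.

The next change starts from compound 3 and leads to compound 4 (`C=C(Br)C(=O)Nc1cccc(/C=C/C(=O)Nc2ccc(Cl)cc2)c1`): 4-chlorophenyl in place of 3-fluorophenyl on an amide-type nitrogen. In words, 4-chlorophenyl replaces 3-fluorophenyl on an amide-type nitrogen.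

Within the data shown here, only one measured step bears on this change: a 14-fold lower number from compound 2 to compound 3 (1.15 log units; beyond the scatter). That step is large and beyond the scatter, and it exchanges 4-fluorophenyl for 3-fluorophenyl at the same amide-type nitrogen. Compound 4 carries a 4-chlorophenyl, so its name pairs it with compound 2 rather than compound 3. On that reading, a clearly higher number is expected in this assay, though perhaps not the full size of the compound 2 gap. Among the measured compounds shown here, no measured pair shows a chlorine exchanged for a fluorine, so the range stays wide and reaches back towards the compound 3 value.

The expected change is a 5.0-fold higher number from compound 3 to compound 4 (0.70 log units; beyond the scatter). For compound 4 the estimated value is 6000 nM, with an expected range of 1500 nM to 20000 nM.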

Compound 4, half-maximal inhibitory concentration: 2800 nM
Compound 4: the middle estimate sits 2.1-fold (0.33 log units) above what was measured, and the stated range covers the measured number.
By their numbers in this assay, from the lowest: compounds 3, 1 and 4 (each within the scatter of the next, the first and the last beyond it); then compound 2.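

On the amide-type nitrogen, a 4-substituted phenyl is not poor as such: chloro in place of fluoro on an aromatic carbon gives a 6.0-fold lower number from compound 2 to compound 4 (0.78 log units; beyond the scatter) in this assay, so the identity of the halogen matters here, not only where it sits on the phenyl. The 3-fluorophenyl still gives the lower number, with a 2.3-fold higher number from compound 3 to compound 4 (0.37 log units; beyond the scatter), but this modest step is much smaller than a 14-fold lower number from compound 2 to compound 3 (1.15 log units; beyond the scatter), so among these three compounds the earlier gap belongs largely to the 4-fluorophenyl and does not carry over in full to the 4-chlorophenyl. Nothing at hand gives a reason for either step.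

The compounds shown do not separate the halogen from its place on the phenyl, since a 3-chlorophenyl is absent from this set, and so it remains unknown whether chloro would also give a lower number there than at the 4-place. Going by these compounds, whether the trend extends beyond halogens also stays open, as a 4-methoxyphenyl, a 4-aminophenyl or an unsubstituted phenyl at this nitrogen would be needed to tell.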